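The compounds below may be only part of what the source reports. "The series", "measured", "known", "first", "only" and "open" are said of these compounds alone.

Measured so far:
Compound 1, `CO/N=C(/CCN1CCN(c2ccccn2)CC1)c1ccccc1C`, in a functional assay on HEK293 cells with D(4) dopamine receptor (Homo sapiens) as the target, read by FLIPR (on this read-out lower numbers stand for an effect already at smaller amounts and higher numbers for an effect only at larger amounts of compound), gives 40.1 nM.
Compound 2, `CO/N=C(\CCN1CCN(c2ccccn2)CC1)c1ccc(Cl)cc1`, in this assay gives 37.6 nM.

Of the two numbers, compound 2 has the lower one, yet the value of compound 1 lies within the scatter of it, so the two compounds cannot be told apart on this read-out. The unmeasured compound 3, `CO/N=C(/CCN1CCN(c2ccccn2)CC1)c1ccc(Cl)cc1`, is related to compound 2 as follows: the two compounds have the same atoms and bonds and differ only in configuration as drawn: 1 of 1 stereo elements differ; a double bond is drawn E in compound 2 and Z in compound 3. Among the compounds with values here, no pair of measured compounds isolates such a change of drawn configuration, so no measured step shows how large its effect is. In the absence of such a step, the expectation for this assay is a step of about the size of the scatter, in either direction, with a wider uncertainty than usual. Accordingly the estimated step is a 1.3-fold higher number from compound 2 to compound 3 (0.12 log units; within the scatter). Compound 3 is expected to give 50 nM in this assay, with a range from 15 nM to 170 nM.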

Compound 3, half-maximal effective concentration: 56.6 nM
The estimate for compound 3 lay 1.1-fold (0.05 log units) below the measured number; the measured number falls inside the stated range.
By their numbers in this assay, from the lowest: compounds 2, 1 and 3 (each within the scatter of the next).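

In this assay, the switch of the double bond from E to Z gives a 1.5-fold higher number from compound 2 to compound 3 (0.18 log units; within the scatter), the first measured size for a change of this kind, and it leaves the two compounds indistinguishable on this read-out. The exchange of groups on the carbon of that double bond gives a 1.4-fold higher number from compound 1 to compound 3 (0.15 log units; within the scatter), so 4-chlorophenyl and 2-methylphenyl cannot be told apart here either. The comparison of compounds 2 and 3 is a clean test of the drawn configuration, because nothing else varies: the fact that compounds 2 and 3 differ only in the configuration as drawn

From the compounds shown here alone, it remains open whether E and Z forms stay this close when the carbon carries 2-methylphenyl or another group, such as 4-methoxyphenyl. Also open, going by these compounds, is how a longer chain in the shared core would read in this assay.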